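The source may hold more compounds than are shown below. What is called first, only, known or untested is meant among the compounds shown, and "the series" means these compounds.

Measured so far:
compound 1 `Cn1c(=O)c(S(=O)(=O)c2ccc(F)cc2F)cc2cnc(Nc3cccc4[nH]ccc34)nc21`, 750 nM
compound 2 `Cn1c(=O)c(S(=O)(=O)c2ccc(F)cc2[N+](=O)[O-])cc2cnc(Nc3ccc4[nH]ccc4c3)nc21`, 1500 nM
compound 3 `Cn1c(=O)c(S(=O)(=O)c2ccc(F)cc2)cc2cnc(Nc3cccc4[nH]ccc34)nc21`, 750 nM

In a functional assay on DU-145 cells (Homo sapiens) for inhibition, read by trypan blue exclusion, with a stated time of 72 h (a lower number here means a stronger inhibitor, a higher number a weaker inhibitor), compound 1 stands level with compound 3 at the lowest number of the three; compound 2 lies higher, although that gap is within the scatter. Compound 3 differs from compound 1 only by no change at the digits printed from compound 1 to compound 3 (within the scatter), which shows that this part of the molecule tolerates the exchange without any shift beyond the scatter.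

Compound 4 `Cn1c(=O)c(S(=O)(=O)c2ccc(F)cc2F)cc2cnc(Nc3ccc4[nH]c(C(=O)O)cc4c3)nc21` is not yet measured. It differs from compound 1 by 2-carboxy-1H-indol-5-yl in place of 1H-indol-4-yl on a nitrogen on an aromatic ring. Going by the values given here, no measured step bears directly on this change: the only single-point step, from compound 1 to compound 3, concerns a different part of the molecule. Compound 2, which carries the indole joined at another position together with a second change, gives 1500 nM, and that is the closest hint available. A modest weakening is therefore expected for compound 4, estimated as a 2.0-fold higher number from compound 1 to compound 4 (0.30 log units; within the scatter), though with wide uncertainty. Compound 4 is expected to give about 1500 nM, within 500 nM to 5000 nM.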

Compound 4, half-maximal inhibitory concentration: 10000 nM
Beside the measured number, compound 4's estimate is 6.7-fold (0.82 log units) below it; the measured number lies above the stated range.
By their numbers in this assay, from the lowest: compounds 1, 3 and 2 (each within the scatter of the next); then compound 4.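

In this assay, the group on a nitrogen on an aromatic ring proves to be a place where a single exchange can cost much activity: putting 2-carboxy-1H-indol-5-yl in place of 1H-indol-4-yl gives a 13-fold higher number from compound 1 to compound 4 (1.12 log units; beyond the scatter). Going by these compounds alone, the earlier compounds showed no such sensitivity, as their only single-place step, a hydrogen in place of a fluoro elsewhere in the molecule, gave no change at the digits printed from compound 1 to compound 3 (within the scatter). Nothing available explains why this exchange weakens inhibition so strongly.

This exchange alters two things at once, the point where the indole is joined and the added carboxy group, and the compounds shown cannot separate them. On these data alone, it also remains open whether plain 1H-indol-5-yl on the core of compound 1, or a methyl ester or primary amide in place of the carboxylic acid, would stay close to compound 1.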